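Ethylamino for Dimethylamino at the Amide Carbonyl

The source may report more compounds than this note shows. Statements on the series, on what has been measured and on what is new or still open speak of the compounds shown alone.

Three compounds have been measured in a functional assay on the whole organism (strain Swiss albino) for inhibition, with Mus musculus as the target, in the writhing test, with stated times of 60 min and 15 min, at a dose of 100 mg/kg by the oral route; on this read-out lower numbers stand for less inhibition and higher numbers for more inhibition at the one dose given (going by the name of the read-out):

Compound 1 `COc1cc2c(cc1OC)C(CC(N)=O)CC2`: 24.6%
Compound 2 `CNC(=O)CC1CCc2cc(OC)c(OC)cc21`: 21.2%
Compound 3 `COc1cc2c(cc1OC)C(CC(=O)N(C)C)CC2`: 22.6%

Compound 3 stands second highest of these three numbers. Its nearest neighbour is compound 2, a number 1.4 percentage points higher from compound 2 to compound 3 (within the scatter), and its furthest is compound 1, a number 2 percentage points lower from compound 1 to compound 3 (within the scatter); both gaps lie within the scatter, so no order among the three can be read.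

Compound 4 `CCNC(=O)CC1CCc2cc(OC)c(OC)cc21` differs from compound 3 by ethylamino in place of dimethylamino on a carbonyl carbon. Going by the values given here, the steps that bear on this are the changes at the amide-type nitrogen, a number 3.4 percentage points lower from compound 1 to compound 2 (within the scatter) and a number 1.4 percentage points higher from compound 2 to compound 3 (within the scatter), and the change at the carbonyl carbon, a number 2 percentage points lower from compound 1 to compound 3 (within the scatter). All three stayed within the scatter. No step beyond the scatter is therefore expected; the expected step is a number 0.4 percentage points higher from compound 3 to compound 4 (within the scatter). Compound 4 is estimated at 23%, with a range from 13% to 33%.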

Compound 4, a percentage reported as inhibition, in the whole organism at one dose (the size of the read-out at that dose, not a potency): 23.6%
Compound 4: the middle estimate sits 0.6 percentage points below what was measured, and the stated range covers the measured number.
By their numbers in this assay, from the lowest: compounds 2, 3, 4 and 1 (each within the scatter of the next).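

In this assay, swapping dimethylamino for ethylamino keeps the same heavy atoms but adds the hydrogen-bond donor counted for ethylamino, and this gives a number 1 percentage points higher from compound 3 to compound 4 (within the scatter). Methyl in place of hydrogen on the chain carbon bound to the amide nitrogen gives a number 2.4 percentage points higher from compound 2 to compound 4 (within the scatter), and ethyl in place of hydrogen on that nitrogen gives a number 1 percentage points lower from compound 1 to compound 4 (within the scatter), so neither the added donor nor the ethyl group separates these amides on this read-out. No supporting measurement is available to interpret these small steps.

Going by these compounds, whether a longer chain such as butyl on the amide nitrogen, a piperidine amide, or a carboxylic acid in place of the amide would step beyond the scatter remains open.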